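Ester Replaces Amide on the Shared Core

The source may hold more compounds than are shown below. What is called first, only, known or untested is meant among the compounds shown, and "the series" means these compounds.

Compound 1 `CCCC(=O)C1=C(C)NC(=O)NC1c1ccoc1` gives 1% in an assay on membranes from CHO cells for displacement of a labelled ligand from adenosine receptor A1 (Homo sapiens), read by scintillation counting, with a stated time of 60 min, tested at 1 uM; on this read-out higher numbers stand for more inhibition at the one concentration tested (going by the name of the read-out) and lower numbers for less inhibition. Compound 2 `CCNC(=O)C1=C(C)NC(=O)NC1c1ccoc1` gives 1%, and the step of no change at the digits printed from compound 1 to compound 2 (within the scatter) shows no movement. Compound 2 thus stands level with compound 1 at the floor of the read-out. Compound 3 `CCC(CC)OC(=O)C1=C(C)NC(=O)NC1c1ccoc1` differs from compound 2 by (pentan-3-yl)oxy in place of ethylamino on a carbonyl carbon. Among the measured compounds shown here, the only measured step, the one from compound 1 to compound 2 on the same carbonyl carbon, was flat, so no change beyond the scatter is expected, and the estimated step is a number 2 percentage points higher from compound 2 to compound 3 (within the scatter). Compound 3 is therefore expected to give 3%, within 0% to 15%.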

Compound 3, a percentage reported as inhibition, at one concentration (the size of the read-out at that concentration, not a potency): 17%
For compound 3 the middle estimate is 14 percentage points below the measured one; the measured number lies above the stated range.
By their numbers in this assay, from the lowest: compounds 1 and 2 (each within the scatter of the next); then compound 3.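

The carbonyl carbon turns out not to be indifferent to its substituent in this assay: (pentan-3-yl)oxy reads higher than ethylamino (a number 16 percentage points higher from compound 2 to compound 3 (beyond the scatter)) and higher than propyl (a number 16 percentage points higher from compound 1 to compound 3 (beyond the scatter)), whereas the earlier swap between those two groups showed nothing. The change replaces the linking atom and the chain together, so these steps cannot assign the gain to either one. Nothing available explains the rise. Going by these compounds, whether the oxygen link or the branched chain carries it stays open. An ethoxy or a (pentan-3-yl)amino group on the same carbonyl carbon would separate the two.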